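This account rests on a few compounds, and the source may have more. Where it says the series, first, only, none or still open, it means among the compounds named here.

Measured compounds:
compound 1 `CN(C)Cc1cc2c(N)nc(-c3ccco3)nc2s1`: 3550 nM
compound 2 `Nc1nc(-c2ccco2)nc2sc(CNC3CC3)cc12`: 1890 nM

In an assay on CHO-K1 cells for antagonist activity at adenosine receptor A1 (Homo sapiens), read by a beta-galactosidase reporter, with stated times of 15 min and 6 h (on this read-out higher numbers stand for weaker inhibition and lower numbers for stronger inhibition), compound 1 gives 3550 nM, and in this assay compound 2 gives 1890 nM. Within the data shown here, compound 2 holds the lowest of the two numbers, with compound 1 the nearest to it; the only measured step, a 1.9-fold lower number from compound 1 to compound 2 (0.27 log units; within the scatter), lies within the scatter, so the two compounds cannot be told apart on these numbers.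

Compound 3 `Nc1nc(-c2ccco2)nc2sc(CN3CCCC3)cc12` has not yet been measured. It differs from compound 2 in one place: pyrrolidin-1-yl in place of cyclopropylamino on a saturated chain carbon bound to an aromatic carbon. Among the measured compounds shown here, the one step that bears on this change is a 1.9-fold lower number from compound 1 to compound 2 (0.27 log units; within the scatter), where dimethylamino gave way to cyclopropylamino at the same saturated chain carbon without a change beyond the scatter. Since the amine groups tried so far at this position have given numbers within the scatter of one another, no step beyond the scatter is expected on moving to pyrrolidin-1-yl. Compound 3 is therefore expected to give 2500 nM in this assay, within a range of 900 nM to 7000 nM. The step this estimate means, a 1.3-fold higher number from compound 2 to compound 3 (0.12 log units; within the scatter), is expected to remain within the scatter.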

Compound 3, inhibition constant: 6430 nM
Beside the measured number, compound 3's estimate is 2.6-fold (0.41 log units) below it; low and high end bracket the measured number.
By their numbers in this assay, from the lowest: compounds 2, 1 and 3 (each within the scatter of the next, the first and the last beyond it).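

At the saturated chain carbon bound to an aromatic carbon, the choice of amine does register in this assay: pyrrolidin-1-yl in place of cyclopropylamino gives a 3.4-fold higher number from compound 2 to compound 3 (0.53 log units; beyond the scatter) and is the one step among these compounds beyond the scatter, though only a modest one. The effect does not extend to every exchange at this carbon, since pyrrolidin-1-yl in place of dimethylamino gives a 1.8-fold higher number from compound 1 to compound 3 (0.26 log units; within the scatter) and leaves compound 1 and compound 3 indistinguishable on these numbers, so only compound 2 and compound 3 can be told apart. The exchange also takes away the hydrogen-bond donor counted on cyclopropylamino and changes a three-membered ring for a five-membered one, but nothing available here links either difference to the step.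

From the compounds shown here alone, whether other secondary amines, such as cyclobutylamino or ethylamino, would group with cyclopropylamino remains open. Going by these compounds, it is equally open where piperidin-1-yl, morpholin-4-yl or a primary amine would fall at this carbon, and so whether the step belongs to ring amines like pyrrolidin-1-yl in general or to this one group.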